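The source may hold more compounds than are shown below. What is called first, only, known or untested is meant among the compounds shown, and "the series" means these compounds.

Within the data shown here, compound 1 `COc1cc(-c2nnc3n2NC(c2ccco2)C(C(=O)c2ccc(Cl)cc2)S3)cc(OC)c1OC` is the only compound here with a plain number in a functional assay on A549 cells (Homo sapiens) for cytotoxicity, read by MTT assay, with a stated time of 48 h; on this read-out lower numbers stand for stronger inhibition and higher numbers for weaker inhibition. In this assay compound 1 gives 51400 nM, a weak inhibition of growth of the lung cancer cells. Among the measured compounds shown here, compound 2 `COc1ccc(C(=O)C2Sc3nnc(-c4cc(OC)c(OC)c(OC)c4)n3NC2c2cccs2)cc1` shares the same core but differs from compound 1 in more than one place, so no single step between the two can be counted. In this assay compound 2 is reported only as a limit, > 100000 nM, meaning the assay did not reach a number for it. One of the two values shown therefore sits at this limit (the limit of > 100000 nM in this assay, at which 1 of the 2 values shown sits), and compound 1 stands as the sole measured point of reference.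

Compound 3 `COc1cc(-c2nnc3n2NC(c2ccco2)C(C(=O)c2ccc(F)c(F)c2)S3)cc(OC)c1OC` has not been measured in this assay. It differs from compound 1 by 3,4-difluorophenyl in place of 4-chlorophenyl on a carbonyl carbon, so the change leaves the core untouched and alters only the aryl group on the carbonyl carbon. For the measured compounds named here, with no measured step of this kind available, the expected step from compound 1 to compound 3 in this assay is a 1.2-fold higher number from compound 1 to compound 3 (0.07 log units; within the scatter), that is, a change within the usual scatter rather than a clear gain or loss. On that basis compound 3 is expected to give about 60000 nM in this assay, with a plausible range from 25000 nM to 150000 nM.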

Compound 3, half-maximal inhibitory concentration: 93700 nM
For compound 3 the middle estimate is 1.6-fold (0.19 log units) below the measured one; measured number inside the range.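

Among these compounds, the swap of 4-chlorophenyl for 3,4-difluorophenyl on a carbonyl carbon gives the first measured step at this position in this assay: a 1.8-fold higher number from compound 1 to compound 3 (0.26 log units; within the scatter). That step lies within the scatter, so this assay cannot tell these two aryl groups apart, and with the core unchanged, this change brings neither a clear gain nor a clear loss in growth inhibition of the lung cancer cells. Both compounds remain weak inhibitors in a part of the scale with little room left, and compound 2 is reported only as a limit: the limit of > 100000 nM in this assay, at which 1 of the 3 values shown sits.

As far as these compounds go, two halogen-bearing phenyl groups are a narrow sample, so it remains open whether any group on this carbonyl carbon can move the number beyond the scatter, for instance a phenyl ring carrying an amine or a carboxylic acid, or a pyridine ring in place of the phenyl ring. From the compounds shown here alone, it is also open whether the same swap would give a similar step on a compound with a different ring on the core, such as the thiophene ring of compound 2.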